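Swapping the amide aryl group in a bis-nitrobenzylidene series

The source may hold more compounds than are shown below. What is called first, only, known or untested is meant among the compounds shown, and "the series" means these compounds.

Of the compounds shown here, three sharing one core have been tested. Compound 1 `COc1ccc(NC(=O)/C=C/C(=O)N2C/C(=C\c3ccc([N+](=O)[O-])cc3)C(=O)/C(=C/c3ccc([N+](=O)[O-])cc3)C2)cc1` gives 940 nM in a functional assay on Molt4/C8 cells (Homo sapiens) for cytotoxicity; a lower number here means a stronger inhibitor, a higher number a weaker inhibitor. Compound 2 `O=C(/C=C/C(=O)N1C/C(=C\c2ccc([N+](=O)[O-])cc2)C(=O)/C(=C/c2ccc([N+](=O)[O-])cc2)C1)Nc1ccc(Cl)c(Cl)c1` gives 600 nM, and compound 3 `O=C(/C=C/C(=O)N1C/C(=C\c2ccc([N+](=O)[O-])cc2)C(=O)/C(=C/c2ccc([N+](=O)[O-])cc2)C1)Nc1ccc(Cl)cc1` gives 1200 nM. Compound 3 thus carries the highest number of the three, yet the two steps leading to it, a 1.3-fold higher number from compound 1 to compound 3 (0.11 log units; within the scatter) and a 2.0-fold higher number from compound 2 to compound 3 (0.30 log units; within the scatter), both sit within the scatter, so no real ordering can be claimed.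

Compound 4 `Cc1ccc(NC(=O)/C=C/C(=O)N2C/C(=C\c3ccc([N+](=O)[O-])cc3)C(=O)/C(=C/c3ccc([N+](=O)[O-])cc3)C2)cc1C` differs from compound 3 by 3,4-dimethylphenyl in place of 4-chlorophenyl on an amide-type nitrogen. Two earlier steps bear on such a change of the aryl group on the amide nitrogen: a 1.6-fold lower number from compound 1 to compound 2 (0.19 log units; within the scatter) and a 1.3-fold higher number from compound 1 to compound 3 (0.11 log units; within the scatter). Neither moved the number beyond the scatter, and the third step, a 2.0-fold higher number from compound 2 to compound 3 (0.30 log units; within the scatter), was equally modest. Since every exchange of this aryl group seen so far left the potency essentially unchanged, compound 4 is expected to show no step beyond the scatter, with a 1.2-fold lower number from compound 3 to compound 4 (0.08 log units; within the scatter). The estimate for compound 4 is therefore 1000 nM, with a range from 450 nM to 2200 nM.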

Compound 4, half-maximal inhibitory concentration: 660 nM
Compound 4: middle estimate off by 1.5-fold (0.18 log units), on the high side; low and high end bracket the measured number.
By their numbers in this assay, from the lowest: compounds 2, 4, 1 and 3 (each within the scatter of the next).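

With a 1.8-fold lower number from compound 3 to compound 4 (0.26 log units; within the scatter) and a 1.1-fold higher number from compound 2 to compound 4 (0.04 log units; within the scatter) and also a 1.4-fold lower number from compound 1 to compound 4 (0.15 log units; within the scatter) as its steps, 3,4-dimethylphenyl on the amide-type nitrogen stays within the scatter of all three earlier aryl groups. The earlier compounds shown here carried methoxy or chloro on the ring, and this one shows that methyl groups also leave this assay unable to separate the four compounds. Nothing measured alongside these numbers offers a reason for this flat picture.

From the compounds shown here alone, all four groups are substituted phenyl rings, so it remains open whether a ring carrying an amine or a carboxylic acid, or a longer chain in place of the ring, would move the number beyond the scatter. Going by these compounds, every compound also shares the same core, and how this position behaves on a different core remains unknown.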